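This account rests on a few compounds, and the source may have more. Where it says the series, first, only, none or still open, it means among the compounds named here.

Compound 3 `COc1cc(NC(C)CCCNC(=O)n2nnc3ccccc32)c2ncccc2c1` is the starting point. In a functional assay on CCRF-CEM cells (Homo sapiens), read by MTT assay, with a stated time of 72 h (on this read-out higher numbers stand for weaker inhibition and lower numbers for stronger inhibition), compound 3 reaches only the limit > 100000 nM, which is the edge of the assay rather than a number (the limit of > 100000 nM in this assay, at which 1 of the 3 values shown sits). Compound 4 `COc1cc(NC(C)CCCNC(=O)NCC2CCCCC2)c2ncccc2c1` replaces the group on the carbonyl carbon: a group of 8 heavy atoms (7 carbon, 1 nitrogen; one six-membered non-aromatic ring of carbon only) in place of a group of 9 heavy atoms (6 carbon, 3 nitrogen; one five-membered aromatic ring with 3 hetero atoms, one six-membered aromatic ring of carbon only), on a carbonyl carbon.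

Within the data shown here, two measured steps bear on this. Compound 1 `CCN(CC)C(=O)NCCCC(C)Nc1cc(OC)cc2cccnc12` gives 142000 nM, and compound 2 `COc1cc(NC(C)CCCNC(=O)NC2CCCC2)c2ncccc2c1` gives 41000 nM. The step of a 3.5-fold lower number from compound 1 to compound 2 (0.54 log units; beyond the scatter) shows a ring-bearing amine on the carbonyl giving a lower number, while an at least 2.4-fold higher number from compound 2 to compound 3 (0.38 log units; beyond the scatter) shows the aromatic group giving a higher one. Since compound 4 carries a ring amine like compound 2, a lower number than the limit is expected, with the step of an at least 2.0-fold lower number from compound 3 to compound 4 (0.30 log units; that floor lies within the scatter). Compound 4 is therefore estimated at 50000 nM, within 20000 nM to 120000 nM.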

Compound 4, half-maximal inhibitory concentration: 22000 nM
For compound 4 the middle estimate is 2.3-fold (0.36 log units) above the measured one, within the range that was stated.
By their numbers in this assay, from the lowest: compounds 4 and 2 (each within the scatter of the next); then compound 1.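

In this assay, the value of compound 3 is a limit of the assay and not a number: the limit of > 100000 nM in this assay, at which 1 of the 4 values shown sits.

Even so, (cyclohexylmethyl)amino on the carbonyl carbon gives an at least 4.5-fold lower number from compound 3 to compound 4 (0.65 log units; beyond the scatter), and against diethylamino it gives a 6.5-fold lower number from compound 1 to compound 4 (0.81 log units; beyond the scatter). Against cyclopentyl the change is a 1.9-fold lower number from compound 2 to compound 4 (0.27 log units; within the scatter), so these two ring-bearing groups cannot be told apart here.

On these data alone, whether phenylamino or morpholine on the same carbonyl carbon would give a similar number stays open. So does whether a ring is needed at all, since diethylamino is the only ringless group shown.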